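The compounds below may be only part of what the source reports. "The series", "measured", "known", "first", "only" and "open" are said of these compounds alone.

Measured compounds:
Compound 1, `CC1=C(C(=O)Nc2ccc(F)cc2)C(c2ccc([N+](=O)[O-])cc2)N=C(SCc2ccc(Cl)cc2)N1`: 22.2%
Compound 2, `CC1=C(C(=O)Nc2ccc(F)cc2)C(c2ccc([N+](=O)[O-])cc2)N=C(SCc2ccc(F)cc2)N1`: 19.6%
Compound 3, `CC1=C(C(=O)Nc2ccc([N+](=O)[O-])cc2)C(c2cccc([N+](=O)[O-])c2)N=C(SCc2ccc(Cl)cc2)N1`: 15.5%

Of the compounds shown here, three have been tested in a functional assay on the whole organism (artery, strain albino) with Rattus norvegicus as the target, with a stated time of 720 min, at a dose of 10 mg/kg by the oral route; on this read-out lower numbers stand for less inhibition and higher numbers for more inhibition at the one dose given (going by the name of the read-out). Compound 1, `CC1=C(C(=O)Nc2ccc(F)cc2)C(c2ccc([N+](=O)[O-])cc2)N=C(SCc2ccc(Cl)cc2)N1`, gives 22.2%. Compound 2, `CC1=C(C(=O)Nc2ccc(F)cc2)C(c2ccc([N+](=O)[O-])cc2)N=C(SCc2ccc(F)cc2)N1`, differs from compound 1 in one place only: fluoro in place of chloro on an aromatic carbon. In this assay, within the data shown here, compound 2 gives 19.6%, so the single change made a step of a number 2.6 percentage points lower from compound 1 to compound 2 (within the scatter). Compound 3, `CC1=C(C(=O)Nc2ccc([N+](=O)[O-])cc2)C(c2cccc([N+](=O)[O-])c2)N=C(SCc2ccc(Cl)cc2)N1`, has a different core from compound 1; how the two cores differ is not broken down here. In this assay compound 3 gives 15.5%, a number within the usual scatter of both compound 1 and compound 2.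

Compound 4, `CC1=C(C(=O)Nc2ccc([N+](=O)[O-])cc2)C(c2cccc([N+](=O)[O-])c2)N=C(SCc2ccc(F)cc2)N1`, has not yet been measured. It stands to compound 3 as compound 2 stands to compound 1: fluoro in place of chloro on an aromatic carbon. The two changes are the same, made on the same kind of ring position and read the same one bond further out. Among the measured compounds shown here, the only guide to its effect is the single step from compound 1 to compound 2, which was within the scatter. On that basis the step from compound 3 to compound 4 in this assay is expected to be about as small, around a number 2 percentage points lower from compound 3 to compound 4 (within the scatter). Because compound 3 gives 15.5%, compound 4 is estimated at 13.5%, most likely between 3% and 24%.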

Compound 4, a percentage reported as inhibition, in the whole organism at one dose (the size of the read-out at that dose, not a potency): 20.1%
Compound 4: middle estimate off by 6.6 percentage points, on the low side, within the range that was stated.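

On the core of compound 3, fluoro in place of chloro in this assay gives a step of a number 4.6 percentage points higher from compound 3 to compound 4 (within the scatter), and this step can be set beside the one from the same change on the core of compound 1: the same change on two cores in this assay, a number 2.6 percentage points lower (within the scatter) from compound 1 to compound 2 and a number 4.6 percentage points higher (within the scatter) from compound 3 to compound 4, 7.2 percentage points apart, within the scatter of two such steps

So, on these two cores, the 4-chlorobenzyl and 4-fluorobenzyl versions cannot be told apart in this measurement, and the two cores give no sign that the change behaves differently from one to the other. This does not show that the change has no effect, or that it would behave alike on every core in the series: two pairs tested at one dose are very few, and a small real effect could lie hidden in the scatter.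

The compounds shown carry only a chloro or fluoro group at this place on the benzyl ring, so it remains open how an amine, a carboxylic acid or a longer chain there would read in this assay. As far as these compounds go, it also remains open whether the two pairs would separate at other doses or at other times after dosing.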